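Aryl swap on the carbonyl carbon: amino for methyl

This account rests on a few compounds, and the source may have more. Where it says the series, first, only, none or still open, it means among the compounds named here.

The series shares one core and varies the aryl group on the carbonyl carbon. Compound 1 `O=C(/C=C/c1ccc2c(c1)B(O)OC2)c1cccs1` gives 14200 nM in a functional assay on HCT-116 cells (Homo sapiens) for cytotoxicity, read by MTT assay, with a stated time of 48 h; a higher number here means a weaker inhibitor, a lower number a stronger inhibitor. Compound 2 `O=C(/C=C/c1ccc2c(c1)B(O)OC2)c1ccc(Cl)cc1` gives 9300 nM in this assay, and compound 3 `Cc1ccc(C(=O)/C=C/c2ccc3c(c2)B(O)OC3)cc1` gives 10500 nM in this assay. Compound 3 thus holds the second highest of the three numbers; its nearest neighbour is compound 2 and its furthest is compound 1, and the step of a 1.4-fold lower number from compound 1 to compound 3 (0.13 log units; within the scatter) as well as the step of a 1.1-fold higher number from compound 2 to compound 3 (0.05 log units; within the scatter) stays within the scatter, as does a 1.5-fold lower number from compound 1 to compound 2 (0.18 log units; within the scatter).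

Compound 4 `Nc1cccc(C(=O)/C=C/c2ccc3c(c2)B(O)OC3)c1` is not yet measured. It differs from compound 3 by 3-aminophenyl in place of 4-methylphenyl on a carbonyl carbon. Going by the values given here, the steps that bear on this change are all three measured swaps of the aryl group on the carbonyl carbon, and none of them moved the number beyond the scatter. Among the compounds with values here, no measured step, however, introduces a hydrogen-bond donor or acceptor on that aryl group, so the data give no direction for such an addition.

On the evidence of the three flat swaps, the step of no change at the digits printed from compound 3 to compound 4 (within the scatter) is expected to lie within the scatter. Compound 4 is therefore estimated at 10500 nM in this assay, within a range from 4000 nM to 28000 nM.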

Compound 4, half-maximal inhibitory concentration: 4500 nM
Compound 4: middle estimate off by 2.3-fold (0.37 log units), on the high side; the range from low to high includes it.
By their numbers in this assay, from the lowest: compound 4; then compounds 2, 3 and 1 (each within the scatter of the next).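

In this assay, going by these compounds alone, the aryl group on the carbonyl carbon no longer looks flat: 3-aminophenyl gives a 2.3-fold lower number from compound 3 to compound 4 (0.37 log units; beyond the scatter) and also a 2.1-fold lower number from compound 2 to compound 4 (0.32 log units; beyond the scatter) as well as a 3.2-fold lower number from compound 1 to compound 4 (0.50 log units; beyond the scatter) in the series, the first steps at this position beyond the scatter, all of them modest. The change keeps the count at 7 heavy atoms and the single six-membered aromatic ring, while the count goes from 0 hydrogen-bond donors and 0 acceptors in 4-methylphenyl to 1 hydrogen-bond donor and 1 acceptor in 3-aminophenyl, so this position can respond to a swap that leaves heavy-atom count unchanged. No measurement offered here accounts for the lower number of compound 4.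

The compounds shown do not settle whether the step belongs to the amine itself or to its place on the ring, a question that 4-aminophenyl and 3-methylphenyl on the same carbonyl carbon would address. Nor do they show whether a hydroxyl, an acetamide or a dimethylamino group at this position would follow compound 4 or fall back towards compounds 1, 2 and 3.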